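Methyl in Place of Methoxy: A Second Look

This account rests on a few compounds, and the source may have more. Where it says the series, first, only, none or still open, it means among the compounds named here.

The measured compounds, with their values in a functional assay on Hs 683 cells (Homo sapiens) for cytotoxicity, read by MTT assay, with a stated time of 72 h; on this read-out lower numbers stand for stronger inhibition and higher numbers for weaker inhibition:
- compound 1 `COc1ccc2[nH]c3c(c4c(c5ccnn53)C(=O)NC4=O)c2c1`: 22000 nM
- compound 2 `Cc1ccc2[nH]c3c(c4c(c5ccnn53)C(=O)NC4=O)c2c1`: 64000 nM
- compound 3 `COc1ccc2[nH]c(-n3cccn3)cc2c1`: 69000 nM

Compound 1 and compound 2 share a core and differ in one place: methyl in place of methoxy on an aromatic carbon. That change gave a 2.9-fold higher number from compound 1 to compound 2 (0.46 log units; beyond the scatter), a step beyond the usual scatter of this assay.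

Compound 3 rests on a different core; how its core differs from that of compound 1 is not broken down here. Its value is close to that of compound 2, and the gap to compound 1 lies beyond the scatter.

Compound 4 `Cc1ccc2[nH]c(-n3cccn3)cc2c1` has not yet been measured. It differs from compound 3 by the same kind of change: methyl in place of methoxy on an aromatic carbon. The surroundings are not identical, since in compound 1 the carbon ring is part of a fused or bridged system of five rings, whereas in compound 3 it is part of a fused or bridged system of two rings.

For compound 4 the expected step is a 2.3-fold higher number from compound 3 to compound 4 (0.37 log units; beyond the scatter), which rests on the earlier step of a 2.9-fold higher number from compound 1 to compound 2 (0.46 log units; beyond the scatter), with wider uncertainty because the core of compound 3 is another one. Compound 4 is therefore expected to give 160000 nM, roughly between 60000 nM and 400000 nM; a value this high may be reported only as a limit.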

Compound 4, half-maximal inhibitory concentration: > 100000 nM
Compound 4 gave a limit, no number; the forecaster's own chance of this, stated with the estimate: 40%; the middle value is on the limit's open side.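

In this assay compound 4 gives > 100000 nM, which is a limit of the assay and not a number. The step from methoxy to methyl on the second core can therefore be read only as a floor, an at least 1.4-fold higher number from compound 3 to compound 4 (0.16 log units; that floor lies within the scatter), and since that floor lies within the scatter, it does not by itself establish a real rise, although nothing in it runs against the rise seen on the first core. What the result does not show is whether the change has the same size on both cores, so it neither confirms nor rules out that the earlier step carries over from one core to the other: the same change on two cores in this assay, a 2.9-fold higher number (0.46 log units; beyond the scatter) from compound 1 to compound 2 and an at least 1.4-fold higher number (0.16 log units; that floor lies within the scatter) from compound 3 to compound 4; the limit leaves it open whether they differ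

The compounds shown pair only methoxy and methyl at this aromatic carbon, one pair on each core, which leaves open how far any trend reaches beyond those two groups. A hydroxyl, an amine, a chlorine or a longer chain such as ethoxy in the same place could show whether the numbers on either core follow the group that sits there, and a change that gives a number on the core of compound 3 would allow a true comparison of sizes.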